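The compounds below may be only part of what the source reports. "The series", "measured", "known", "first", "only" and "open" are said of these compounds alone.

Measured compounds:
- compound 1 `CCCCCCC#Cc1ccc(S(=O)(=O)Nc2cccc(-c3csc(NC(C)=O)n3)c2)cc1`: 40.7% in a functional assay on A-375 cells (Homo sapiens) for antiproliferative activity, read by trypan blue exclusion, with a stated time of 48 h, tested at 1 uM; on this read-out higher numbers stand for a weaker effect at the one concentration tested and lower numbers for a stronger effect
- compound 2 `CC(=O)Nc1nc(-c2cccc(NS(=O)(=O)c3cccc(C#CCO)c3)c2)cs1`: 85.4% in this assay

Of the two numbers, compound 1 stands lowest, and so shows the stronger effect at the one concentration used. Compound 2 lies well above it, by a gap beyond the usual scatter, though the two structures differ in more than one place, so the gap cannot be tied to a single change.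

Compound 3 `CCCCCC/C=C\c1ccc(S(=O)(=O)Nc2cccc(-c3csc(NC(C)=O)n3)c2)cc1` is the unmeasured compound. It differs from compound 1 in one place: a group of 8 heavy atoms (8 carbon; no ring) in place of a group of 8 heavy atoms (8 carbon; no ring), on an aromatic carbon. The chain keeps its length; only the bond outside the ring changes from triple to double. For this the step of a number 6.3 percentage points higher from compound 1 to compound 3 (within the scatter) is expected to be small, in the direction of a slightly weaker effect, and it may well fall within the scatter. On that basis compound 3 is estimated at 47%, with a range from 28% to 70%.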

Compound 3, a percentage reported as activity, at one concentration (the size of the read-out at that concentration, not a potency): 48.8%
Estimate against measurement, compound 3: 1.8 percentage points below, within the range that was stated.
By their numbers in this assay, from the lowest: compounds 1 and 3 (each within the scatter of the next); then compound 2.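

In this assay, among the compounds shown here, the first comparison that differs in only one place gives a number 8.1 percentage points higher from compound 1 to compound 3 (within the scatter): the oct-1-yn-1-yl chain gives way to a chain of the same size with a double bond instead of a triple bond, on an aromatic carbon para to a large group. At this position, then, the two chains cannot be told apart in this assay, so the triple bond is not required for the effect seen at the one concentration tested. No measurement shown gives a reason for this result.

From the compounds shown here alone, it remains open whether a fully saturated octyl chain would read the same at this position. A much shorter ethyl group, or a chain ending in a carboxylic acid or an amine, is equally untested by the compounds shown.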